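Methyl on the Phenylpiperazine: Expecting Little Change

The source may report more compounds than this note shows. Statements on the series, on what has been measured and on what is new or still open speak of the compounds shown alone.

Measured compounds so far:
- compound 1, `Nc1ccccc1NC(=O)c1ccc(CSC(=S)N2CCN(c3ccccc3)CC2)cc1`, 73.1%
- compound 2, `Nc1ccccc1NC(=O)c1ccc(CSC(=S)N2CCc3cc(Cl)ccc32)cc1`, 65.1%
- compound 3, `CC1CCCCN1C(=S)SCc1ccc(C(=O)Nc2ccccc2N)cc1`, 76.3%

All three share the same core and were tested in a functional assay on HeLa cells (Homo sapiens) for antiproliferative activity, read by CCK-8 assay, with a stated time of 72 h, tested at 8 uM; on this read-out higher numbers stand for a stronger effect at the one concentration tested and lower numbers for a weaker effect. Compound 1 gives 73.1%, the second highest of the three numbers; its nearest neighbour is compound 3 with 76.3%, and its furthest is compound 2 with 65.1%, yet both gaps lie within the scatter, so no order among the three can be claimed from them. The one step listed, a number 11.2 percentage points higher from compound 2 to compound 3 (beyond the scatter), swaps the whole group on the thiocarbonyl carbon and is beyond the scatter.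

Compound 4, `Cc1ccc(N2CCN(C(=S)SCc3ccc(C(=O)Nc4ccccc4N)cc3)CC2)cc1`, differs from compound 1 by methyl in place of hydrogen on an aromatic carbon, para to a large group. Going by the values given here, no measured step touches this kind of change: the step from compound 2 to compound 3 concerns a different group, so it gives no guidance. With nothing to point either way, the expectation is a step of about a number 0.1 percentage points lower from compound 1 to compound 4 (within the scatter), that is, none beyond the scatter. Compound 4 is therefore estimated at 73%, expected to fall between 60% and 84%.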

Compound 4, a percentage reported as inhibition, at one concentration (the size of the read-out at that concentration, not a potency): 24%
Beside the measured number, compound 4's estimate is 49 percentage points above it, outside the stated range (below it).
By their numbers in this assay, from the lowest: compound 4; then compounds 2, 1 and 3 (each within the scatter of the next, the first and the last beyond it).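

In this assay, the change from phenyl to 4-methylphenyl proves far from silent, giving a number 49.1 percentage points lower from compound 1 to compound 4 (beyond the scatter). A single added methyl, para to a large group, is therefore enough to change this read-out strongly, something that the earlier compounds could not reveal, as their one listed step, a number 11.2 percentage points higher from compound 2 to compound 3 (beyond the scatter), replaced a whole group on the thiocarbonyl carbon. The data available here offer no explanation for this drop.

As far as these compounds go, whether a methoxy group, a chlorine atom or an ethyl group on the same aromatic carbon would bring a similar drop remains open. Also unresolved is whether the same methyl would have this effect on another carbon of that ring, and since each number comes from one concentration, the step does not give a change in potency.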